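Swapping an Aryl Arm for a Short Chain

The compounds below may be only part of what the source reports. "The series", "measured", "known", "first", "only" and "open" are said of these compounds alone.

Measured so far:
compound 1, `CCCCc1cnc(C(Cc2ccc(-c3ccccc3C(=O)O)cc2)C(C)C)[nH]1`, 4620 nM
compound 2, `Cc1cccc(Cc2cnc(CCc3ccc(-c4ccccc4C(=O)O)cc3)[nH]2)c1`, 4310 nM

Both values come from an in vitro functional assay on cells for agonist activity at Bombesin receptor subtype-3 (Homo sapiens), read by luminescence and calcium flux; a higher number here means that more compound is needed for the effect, a lower number that less compound is needed. Compound 2 has the lower of the two numbers, but the gap to compound 1 is within the scatter of repeated measurements, so the two compounds cannot be told apart on this evidence.

The next compound, compound 3, `CCCCc1cnc(CCc2ccc(-c3ccccc3C(=O)O)cc2)[nH]1`, is not yet measured. It differs from compound 2 in a single spot: propyl in place of 3-methylphenyl on a saturated chain carbon bound to an aromatic carbon. Put another way, the 3-methylbenzyl arm becomes a butyl chain, which is the same chain that compound 1 carries on its core.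

Going by the values given here, no step between two measured compounds is available to guide the expectation, because no pair here differs in only one place. The closest hint is that compound 1, with its butyl chain, gives 4620 nM, a number within the scatter of compound 2. A modest rise, perhaps just beyond the scatter, is expected for the step of a 1.5-fold higher number from compound 2 to compound 3 (0.18 log units; within the scatter). Compound 3 is therefore estimated at 6500 nM, with a likely range from 2000 nM to 20000 nM.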

Compound 3, half-maximal effective concentration: 2710 nM
For compound 3 the middle estimate is 2.4-fold (0.38 log units) above the measured one; measured number inside the range.
By their numbers in this assay, from the lowest: compounds 3, 2 and 1 (each within the scatter of the next).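

In this assay, the change from the 3-methylbenzyl arm to a butyl chain can now be read directly as a 1.6-fold lower number from compound 2 to compound 3 (0.20 log units; within the scatter), and since this step lies within the scatter, the aromatic ring of that arm can give way to an open chain with no difference that these measurements can detect. The second step, hydrogen in place of isopropyl on a saturated chain carbon bound to an aromatic carbon and a saturated chain carbon, is a 1.7-fold lower number from compound 1 to compound 3 (0.23 log units; within the scatter), which also lies within the scatter, so neither this branch nor the arm swap separates the compounds on this evidence. No other measurement shown here bears on these two results.

Going by these compounds, with all three compounds close together, it remains open whether any change at these two places can produce a step beyond the scatter, for example a longer chain such as octyl, or a chain ending in an amine in place of butyl. Whether a bulkier branch such as tert-butyl in place of isopropyl would behave the same way also remains unanswered.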